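A few compounds are considered here, and "the series" means these few. Any claim that something is new, unique, unknown or untested is made for them only; others in the source may bear on it.

Measured compounds:
- compound 1, `COc1cc(C)cc(-c2c(-c3ccnc(-c4ccc(C(C)=O)cc4)c3)cnn2CC#N)c1`, gives > 100000 nM in a functional assay on NCI-H460 cells (Homo sapiens) for inhibition, read by sulforhodamine B assay, with a stated time of 48 h (on this read-out higher numbers stand for lower toxicity in this test and lower numbers for higher toxicity in this test), a limit of the assay rather than a number.
- compound 2, `Cc1cc(O)cc(-c2nn(CC#N)cc2-c2ccnc(-c3ccc(Oc4ccccc4)cc3)c2)c1`, gives 6850 nM.
- compound 3, `COc1cc(C)cc(-c2nn(CC#N)cc2-c2ccnc(-c3ccc(N(C)C)cc3)c2)c1`, gives 94700 nM.

All three share one core and differ at two ends: the group on the left-hand phenyl ring and the tail on the pyridine-linked phenyl ring. Compound 1 sits at the limit (the limit of > 100000 nM in this assay, at which 1 of the 3 values shown sits). Of the two numbers in this assay, compound 3 has the higher one, and the number of compound 2 lies lower by a gap beyond the usual scatter; since the two compounds differ at both ends, the values alone do not say which end accounts for that.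

Compound 4, `Cc1cc(O)cc(-c2nn(CC#N)cc2-c2ccnc(-c3ccc(N(C)C)cc3)c2)c1`, is not yet measured. It differs from compound 3 by one change: hydrogen in place of methyl on an oxygen on an aromatic ring. Within the data shown here, no pair of measured compounds differs by this change alone, so its size is not known from the data. Among the measured compounds shown here, a modest move toward a lower number is expected, with a 2.4-fold lower number from compound 3 to compound 4 (0.37 log units; beyond the scatter) as the estimated step, because compound 2 gives 6850 nM as the only hydroxy compound measured while compound 3 gives 94700 nM as the only dimethylamino compound measured. For compound 4 a value of 40000 nM is expected, within 10000 nM to 150000 nM.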

Compound 4, concentration lethal to 50% of the cells: 70500 nM
Compound 4: the middle estimate sits 1.8-fold (0.25 log units) below what was measured; the measured number falls inside the stated range.
By their numbers in this assay, from the lowest: compound 2; then compounds 4 and 3 (each within the scatter of the next). At a limit, above all of these: compound 1.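

In this assay the change from methoxy to hydroxy on the 3-methoxy-5-methylphenyl group, with the dimethylamino tail held the same, gives a 1.3-fold lower number from compound 3 to compound 4 (0.13 log units; within the scatter) and so, taken alone, does not separate the two compounds at this position. With the hydroxy group held the same, dimethylamino in place of phenoxy gives a 10-fold higher number from compound 2 to compound 4 (1.01 log units; beyond the scatter) and so, among these compounds, the clear difference goes with the tail rather than with the group on the oxygen. The data shown give no measured property that would explain either step.

Still open, going by these compounds, is whether methoxy and hydroxy would stay as close with the phenoxy tail in place. Also open, on these data alone, is how a longer chain on that oxygen, such as ethoxy, or a carboxylic acid on the tail would read in this assay here.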